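This account rests on a few compounds, and the source may have more. Where it says the series, first, only, none or still open, it means among the compounds named here.

Measured in an ADME assay on MDCK cells (Canis lupus familiaris) for cytotoxicity, read by microscopy, with a stated time of 72 h; a lower number here means that less compound is tolerated, a higher number that more compound is tolerated:

compound 1 `COC(=O)C[C@H](NC(=O)OC(C)(C)C)C(=O)N(Cc1ccccc1)C1(C(=O)NCc2ccccc2)CCN(Cc2ccccc2)CC1` gives > 100000 nM.
compound 2 `COC(=O)C[C@H](NC(=O)OC(C)(C)C)C(=O)N(Cc1ccc(F)cc1)C(C)(C)C(=O)NCc1ccccc1` gives 20000 nM.
compound 3 `COC(=O)C[C@H](NC(=O)OC(C)(C)C)C(=O)N(Cc1ccc(F)cc1)C1(C(=O)NC2CCCCC2)CCN(Cc2ccccc2)CC1` gives 100000 nM.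

For compound 1 the value reported is a limit of the assay rather than a number; compound 1 stands at the limit of > 100000 nM in this assay, at which 1 of the 3 values shown sits. Compound 2 and compound 3 give numbers, and of those two compound 3 is tolerated at the higher concentration.

Compound 4 `COC(=O)C[C@H](NC(=O)OC(C)(C)C)C(=O)N(Cc1ccccc1F)C1(C(=O)NCc2ccccc2)CCN(Cc2ccccc2)CC1` differs from compound 1 in one place: fluoro in place of hydrogen on an aromatic carbon. Among the compounds with values here, no step between two measured compounds is recorded here, so in this assay no change beyond the scatter is expected from this exchange, and the expected step is a number no higher from compound 1 to compound 4 (the limit leaves the size open). Compound 4 is accordingly estimated at 100000 nM, with a range from 50000 nM to 200000 nM.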

Compound 4, minimum cytotoxic concentration: 20000 nM
Beside the measured number, compound 4's estimate is 5.0-fold (0.70 log units) above it; measured number below the stated range.
By their numbers in this assay, from the lowest: compounds 2 and 4 (each within the scatter of the next); then compound 3.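

In this assay, fluoro in place of hydrogen on an aromatic carbon, ortho to a large group, gives an at least 5.0-fold lower number from compound 1 to compound 4 (0.69 log units; beyond the scatter). Within the data shown here, this is the first pair differing in one place, and it shows that this small exchange on the benzyl ring can lower the tolerated concentration beyond the scatter. Compound 1 stands at a limit and not at a number, so the full size of the step stays open: the limit of > 100000 nM in this assay, at which 1 of the 4 values shown sits.

The compounds shown leave open whether chloro or methyl at this same place would lower the number as well.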